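Trifluoromethyl for Methyl: Expected Cytotoxicity of Compound 4

The source may hold more compounds than are shown below. What is called first, only, known or untested is meant among the compounds shown, and "the series" means these compounds.

In a functional assay on HCT-15 cells (Homo sapiens) for cytotoxicity, read by sulforhodamine B assay, with a stated time of 48 h, tested at 50 uM (a lower number here means less inhibition, a higher number more inhibition at the concentration tested (going by the name of the read-out)), three compounds have been measured:
compound 1 `Cc1ccc(Nc2nccc(-c3c(C)nc4ccccn34)n2)cc1` gives 95.2%
compound 2 `Cc1nc2ccccn2c1-c1ccnc(Nc2ccc(C=O)s2)n1` gives 85.4%
compound 3 `Cc1ccc(Nc2nccc(-c3cnc4ccccc4c3)n2)cc1` gives 30.3%

Compound 1 stands highest of these three numbers. Compound 2 is nearest, with a number 9.8 percentage points lower from compound 1 to compound 2 (within the scatter), so the two cannot be told apart. Compound 3 is furthest; its lower number lies beyond the scatter, but it carries a different core, so it says nothing about the step at hand.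

Compound 4 `Cc1nc2ccccn2c1-c1ccnc(Nc2ccc(C(F)(F)F)cc2)n1` keeps the core of compound 1 and differs in one place: trifluoromethyl in place of methyl on an aromatic carbon. Among the measured compounds shown here, the only measured step at the same part of the molecule is the one from compound 1 to compound 2, where the whole group on the nitrogen was exchanged and the number stayed within the scatter. For the measured compounds named here, no measured step swaps just the group on this ring, so a change within the scatter is expected, with a number 7.2 percentage points lower from compound 1 to compound 4 (within the scatter). Compound 4 is therefore estimated at 88%, with a range from 68% to 98%.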

Compound 4, a percentage reported as inhibition, at one concentration (the size of the read-out at that concentration, not a potency): 88.6%
Estimate against measurement, compound 4: 0.6 percentage points below, and the stated range covers the measured number.
By their numbers in this assay, from the lowest: compound 3; then compounds 2, 4 and 1 (each within the scatter of the next).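

Exchanging only the group on this ring gives a number 6.6 percentage points lower from compound 1 to compound 4 (within the scatter), so in this assay the two compounds cannot be told apart. On this aromatic carbon, para to a large group, the bulkier trifluoromethyl therefore leaves the read-out in the same range as methyl. Nothing available explains why the number holds.

On these data alone, whether an amine, a carboxylic acid or a longer chain at this position would do the same stays open. Readings at one concentration also leave open how the potencies of compound 1 and compound 4 compare.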